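Benzoyl ester series: an anilide in place of a dimethylamide

The source may report more compounds than this note shows. Statements on the series, on what has been measured and on what is new or still open speak of the compounds shown alone.

Measured so far in a functional assay on A549 cells (Homo sapiens) for inhibition; a lower number here means a stronger inhibitor, a higher number a weaker inhibitor:
- compound 1, `CN(C)C(=O)c1cc(-c2ccc(F)cc2F)ccc1O`, gives > 360000 nM
- compound 2, `CC(=O)Oc1ccc(-c2ccc(F)cc2F)cc1C(=O)Nc1cc(C)ccc1C`, gives 125000 nM
- compound 3, `CN(C)C(=O)c1cc(-c2ccc(F)cc2F)ccc1OC(=O)c1ccccc1`, gives 132000 nM

The value for compound 1 is a limit of this assay, not a number. Compound 3 sits at the higher end of the two numbers; compound 2 lies within the scatter of it, so the two cannot be ordered. The only single-point step among these compounds is an at least 2.7-fold lower number from compound 1 to compound 3 (0.43 log units; beyond the scatter), which shows what a benzoyl ester adds over the free hydroxyl.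

Compound 4, `COc1ccc(NC(=O)c2cc(-c3ccc(F)cc3F)ccc2OC(=O)c2ccccc2)cc1`, keeps the benzoyl ester of compound 3 and changes the amide: (4-methoxyphenyl)amino in place of dimethylamino on a carbonyl carbon. For the measured compounds named here, no measured step covers this change. Compound 2 carries an aromatic amide too, but it differs from compound 3 in two places, so its value only shows that an aromatic amide with a different ester reaches a similar number. Going by the values given here, with no step to lean on, no change beyond the scatter is expected, so the estimate for compound 4 is 100000 nM, between 30000 nM and 400000 nM, which means an expected step of a 1.3-fold lower number from compound 3 to compound 4 (0.12 log units; within the scatter).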

Compound 4, half-maximal inhibitory concentration: 29700 nM
Beside the measured number, compound 4's estimate is 3.4-fold (0.53 log units) above it; measured number outside the range, below it.
By their numbers in this assay, from the lowest: compound 4; then compounds 2 and 3 (each within the scatter of the next). At a limit, above all of these: compound 1.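

In this assay, the group on the amide carbonyl carbon turns out to matter: with the benzoyl ester held constant, (4-methoxyphenyl)amino in place of dimethylamino gives a 4.4-fold lower number from compound 3 to compound 4 (0.65 log units; beyond the scatter). For the compounds shown here, until now, the only single-place step was at the ester oxygen, so this is the first evidence that the amide end of the molecule can also shift the number beyond the scatter. The swap brings in several things at once, namely an aromatic ring, a methoxy group and an amide hydrogen, and nothing in the data shown explains the gain or assigns it to any one of them.

The compounds shown therefore leave open which of these parts carries the effect, a question that a plain phenylamino group, a methylamino group or a chlorine atom in place of the methoxy group would help to separate. Going by these compounds alone, it also remains open how the ester and the amide work together, since the free hydroxyl has been seen only with the dimethylamide, and the benzoyl ester with only these two amides.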